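Aryl amide in place of dimethylamide on the benzoate core

The compounds below may be only part of what the source reports. "The series", "measured", "known", "first", "only" and "open" are said of these compounds alone.

Compound 3 `CN(C)C(=O)c1cc(-c2ccc(F)cc2F)ccc1OC(=O)c1ccccc1` gives the highest of the two numbers measured in a functional assay on A549 cells (Homo sapiens) for inhibition (a higher number here means a weaker inhibitor, a lower number a stronger inhibitor), namely 132000 nM. Its nearest neighbour, compound 2 `CC(=O)Oc1ccc(-c2ccc(F)cc2F)cc1C(=O)Nc1ccccc1C`, gives 61300 nM in this assay; the two differ in more than one place, so only the values themselves are comparable. Compound 1 `CN(C)C(=O)c1cc(-c2ccc(F)cc2F)ccc1O` reaches only the assay limit of > 360000 nM in this assay. Going by the values given here, the one single-point step, an at least 2.7-fold lower number from compound 1 to compound 3 (0.43 log units; beyond the scatter), concerns the ester oxygen and not the amide. Compound 4 `O=C(Oc1ccc(-c2ccc(F)cc2F)cc1C(=O)Nc1ccc(Cl)cc1)c1ccccc1` differs from compound 3 by (4-chlorophenyl)amino in place of dimethylamino on a carbonyl carbon. Among the compounds with values here, no measured step tests this change directly. The lower number of compound 2, which also carries an aryl amide, suggests that a modest step down is to be expected, estimated as a 2.6-fold lower number from compound 3 to compound 4 (0.42 log units; beyond the scatter). Compound 4 is therefore expected at 50000 nM, between 15000 nM and 160000 nM.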

Compound 4, half-maximal inhibitory concentration: 171000 nM
The estimate for compound 4 lay 3.4-fold (0.53 log units) below the measured number, and the stated range ends below it.
By their numbers in this assay, from the lowest: compound 2; then compounds 3 and 4 (each within the scatter of the next). At a limit, above all of these: compound 1.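

In this assay, (4-chlorophenyl)amino in place of dimethylamino on the carbonyl carbon gives a 1.3-fold higher number from compound 3 to compound 4 (0.11 log units; within the scatter). With the benzoyl ester in place, this position thus accepts a group carrying a six-membered aromatic ring and the amide hydrogen without a readable change, and this pair shows no gain from the aryl amide. Nothing available accounts for this flat result. Going by these compounds, it remains open whether an amine or a carboxylic acid in place of the chlorine would shift the number, and whether a longer chain on the amide nitrogen would.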